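A few compounds are considered here, and "the series" means these few. Any claim that something is new, unique, unknown or untested is made for them only; others in the source may bear on it.

Working notes on the series, read in a functional assay on SMMC-7721 cells (Homo sapiens) for cytotoxicity, read by MTT assay, with a stated time of 24 h; on this read-out higher numbers stand for weaker inhibition and lower numbers for stronger inhibition. Compound 1 (`CN1C/C(=C\c2cccnc2)C(=O)/C(=C/c2cc([N+](=O)[O-])ccc2F)C1`) gives 6170 nM. Going by the values given here, compound 2 (`Cc1ccc(S(=O)(=O)N2C/C(=C\c3cccnc3)C(=O)/C(=C/c3ccccc3F)C2)cc1`) gives 10300 nM, a number within the scatter of compound 1, the only other measured compound. Next comes compound 3 (`N#Cc1ccc(S(=O)(=O)N2C/C(=C\c3cccnc3)C(=O)/C(=C/c3ccccc3F)C2)cc1`), with cyano in place of methyl on an aromatic carbon, para to a large group: cyano in place of methyl on an aromatic carbon. Among the compounds with values here, no measured pair shows this change, so the expected step in this assay is none beyond the scatter, estimated as a 1.3-fold lower number from compound 2 to compound 3 (0.11 log units; within the scatter). Compound 3 is estimated at 8000 nM, with an expected range of 3000 nM to 20000 nM.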

Compound 3, half-maximal inhibitory concentration: 15400 nM
Compound 3: the middle estimate sits 1.9-fold (0.28 log units) below what was measured, within the range that was stated.
By their numbers in this assay, from the lowest: compounds 1, 2 and 3 (each within the scatter of the next, the first and the last beyond it).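

In this assay the series gains its first comparison that differs in one place: cyano in place of methyl on an aromatic carbon, para to a large group (a 1.5-fold higher number from compound 2 to compound 3 (0.17 log units; within the scatter)). At this position, the change from 4-methylphenyl to 4-cyanophenyl therefore stays inside the scatter. Nothing on hand offers an explanation for this reading.

Still open, going by these compounds, is how other groups at this position would read, such as an amine or a carboxylic acid. The compounds shown also leave open whether the same change would read alike with other substituents on the shared core.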